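The source may hold more compounds than are shown below. What is called first, only, known or untested is meant among the compounds shown, and "the series" means these compounds.

Compound 2, with the structure `Cc1nsc2c1ncn2[C@@H]1O[C@H](CO)[C@@H](O)[C@@H]1O`, is known only as a limit: in a functional assay on KB cells (Homo sapiens) for antiproliferative activity (on this read-out higher numbers stand for weaker inhibition and lower numbers for stronger inhibition), compound 2 gives > 100000 nM, which is a limit of the assay rather than a number. Compound 1, with the structure `Cc1nsc2c1ncn2[C@H]1C[C@H](O)[C@@H](CO)O1`, gives > 100000 nM in this assay, again a limit. The step that the two limits leave unreadable from compound 1 to compound 2 therefore cannot be read, since both values sit at the limit described by the limit of > 100000 nM in this assay, at which 2 of the 2 values shown sit. Compound 3, with the structure `Cc1nsc2c1ncn2[C@@H]1O[C@H](CO)[C@@H](O)[C@H]1O`, differs from compound 2 only in configuration: the two compounds have the same atoms and bonds and differ only in configuration as drawn: 1 of 4 stereo elements differ; a stereocentre at a saturated ring carbon is drawn S in compound 2 and R in compound 3. Among the measured compounds shown here, no measured step shows what such a change alone does. Compound 3 is expected to remain at the limit, estimated at 100000 nM, between 30000 nM and 300000 nM. The expected step from compound 2 to compound 3 is therefore a number no higher from compound 2 to compound 3 (the limit leaves the size open), none beyond the scatter.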

Compound 3, half-maximal inhibitory concentration: 90000 nM
For compound 3 the middle estimate is 1.1-fold (0.05 log units) above the measured one, within the range that was stated.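

In this assay, among the compounds shown here, compound 3 gives 90000 nM, the only value shown that is a number and not a limit. Changing one stereocentre at a saturated ring carbon gives an at least 1.1-fold lower number from compound 2 to compound 3 (0.04 log units; that floor lies within the scatter), while hydroxy in place of hydrogen on a saturated ring carbon gives an at least 1.1-fold lower number from compound 1 to compound 3 (0.04 log units; that floor lies within the scatter). Both steps are therefore only floors, and neither floor clears the scatter.

Going by these compounds, the step between the two limits cannot be read, so how far compound 1 and compound 2 truly lie from compound 3 stays open. Also open, on these data alone, is what an amine or a fluorine in place of this hydroxy would do.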